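The compounds below may be only part of what the source reports. "The series", "measured", "known", "first", "only" and "open" are said of these compounds alone.

Measured so far:
- compound 1 `CCOC(=O)C1=Cc2ccccc2OC1(OCc1cc(-c2ccc3ccccc3c2)no1)C(F)(F)F`: 65400 nM
- compound 2 `CCOC(=O)C1=Cc2ccccc2OC1(OCc1cc(-c2ccc(OC)cc2)no1)C(F)(F)F`: > 150000 nM
- compound 3 `CCOC(=O)C1=Cc2ccccc2OC1(OCc1cc(-c2ccc(Cl)cc2)no1)C(F)(F)F`: 18200 nM

In a functional assay on MCF7 cells (Homo sapiens) for inhibition, read by MTT assay, with a stated time of 24 h (a higher number here means a weaker inhibitor, a lower number a stronger inhibitor), compound 1 sits at the higher of the two numbers given; its nearest neighbour is compound 3, reached by a 3.6-fold lower number from compound 1 to compound 3 (0.56 log units; beyond the scatter). Compound 2 reports a limit only (the limit of > 150000 nM in this assay, at which 1 of the 3 values shown sits); the corresponding step is an at least 2.2-fold higher number from compound 1 to compound 2 (0.36 log units; beyond the scatter), and between the two aryl variants the step is an at least 8.2-fold lower number from compound 2 to compound 3 (0.91 log units; beyond the scatter).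

Compound 4 `O=C(O)C1=Cc2ccccc2OC1(OCc1cc(-c2ccc3ccccc3c2)no1)C(F)(F)F` differs from compound 1 by hydrogen in place of ethyl on an oxygen next to a carbonyl group. Within the data shown here, none of the measured steps touches this position; all three concern the aromatic group on the isoxazole, so nothing here sets a direction for the ester-to-acid change. The working expectation for compound 4 is therefore a number near that of compound 1, with a 1.2-fold higher number from compound 1 to compound 4 (0.09 log units; within the scatter) not beyond the scatter, estimated at 80000 nM within 25000 nM to 250000 nM.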

Compound 4, half-maximal inhibitory concentration: > 150000 nM
Compound 4: no number, only a limit; the forecaster's own chance of this, stated with the estimate: 35%; at least 1.8-fold (0.27 log units) between middle value and limit.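

The ester position is not neutral: replacing ethoxycarbonyl with carboxy gives an at least 2.2-fold higher number from compound 1 to compound 4 (0.36 log units; beyond the scatter) in this assay. Compound 4 reports only a limit, > 150000 nM, so this change has a direction but no measured size. This limit is shared within the series: the limit of > 150000 nM in this assay, at which 2 of the 4 values shown sit.

A primary amide or a longer alkyl ester at this position could show whether the ethyl ester itself matters or whether other replacements hold the number of compound 1. On these data alone, it also remains open whether carboxy gives a similar step with 4-chlorophenyl in place of naphthalen-2-yl.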